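Series notes: the step from compound 2 to compound 3

The compounds below may be only part of what the source reports. "The series", "measured", "known", "first", "only" and "open" are said of these compounds alone.

Measured so far:
compound 1 `c1ccc(-c2nc(-c3c[nH]c4ccccc34)co2)cc1` gives 171000 nM
compound 2 `Oc1ccc(-c2nc(-c3c[nH]c4ccccc34)co2)cc1` gives 103000 nM

Both numbers come from a functional assay on MDA-MB-231 cells (Homo sapiens) for cytotoxicity, read by MTT assay, with a stated time of 48 h; a higher number here means a weaker inhibitor, a lower number a stronger inhibitor. Going by the values given here, the only step so far, a 1.7-fold lower number from compound 1 to compound 2 (0.22 log units; within the scatter), lies within the scatter, so the two compounds are not separated by it. On the numbers shown compound 2 stands lowest of the two, with compound 1 nearest.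

Compound 3 `c1ccc2c(-c3cocn3)c[nH]c2c1` has not been measured. Its difference from compound 2 is hydrogen in place of 4-hydroxyphenyl on an aromatic carbon. The step from compound 1 to compound 2 touched only the hydroxy group on that same 4-hydroxyphenyl. Among the compounds with values here, no measured step removes the whole group, so that one step bears on the present change only loosely, and its size gives no direct guide. What it does show is that changing the hydroxy group alone left the number within the scatter. Removing the whole 4-hydroxyphenyl is a larger change than any measured one. Within the data shown here, with no step pointing either way, the expected step is a 2.1-fold higher number from compound 2 to compound 3 (0.33 log units; beyond the scatter), a number near that of compound 2 or somewhat higher. Compound 3 is therefore estimated at 220000 nM, in the range 90000 nM to 550000 nM.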

Compound 3, half-maximal inhibitory concentration: 103000 nM
Compound 3: the middle estimate sits 2.1-fold (0.33 log units) above what was measured; the range from low to high includes it.
By their numbers in this assay, from the lowest: compounds 2, 3 and 1 (each within the scatter of the next).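

In this assay, replacing 4-hydroxyphenyl with hydrogen on the aromatic carbon next to the ring nitrogen and next to the ring oxygen gives no change at the digits printed from compound 2 to compound 3 (within the scatter) and replacing phenyl with hydrogen at that carbon gives a 1.7-fold lower number from compound 1 to compound 3 (0.22 log units; within the scatter), so neither aromatic group is separated from hydrogen here. The earlier step showed this only for the hydroxy group on the aromatic ring, whereas these two steps extend it to the loss of the whole ring, so compounds 1, 2 and 3 now form a single group within the scatter, and a six-membered aromatic ring at this carbon is not needed to reach these numbers. Nothing available explains why the numbers stay together across these changes.

On these data alone, what remains open is whether any group at this carbon can move the number beyond the scatter, for example a primary amine, a carboxylic acid or a longer alkyl chain. Also open is whether changes elsewhere on the shared core would separate compounds in this assay, since all the steps shown fall at this one carbon or on the group it carries.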